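This account rests on a few compounds, and the source may have more. Where it says the series, first, only, none or still open, it means among the compounds named here.

Measured so far:
compound 1 `O=C(NNS(=O)(=O)c1ccccc1F)c1cc(F)cc(-c2ccccn2)c1` — 131 uL/min
compound 2 `Cc1cc(-c2ncccn2)cc(C(=O)NNS(=O)(=O)c2ccccc2)c1F` — 279 uL/min

Both compounds were run in an ADME assay on microsomes from liver (Mus musculus) for metabolic stability, read by HPLC, using NADPH, with a stated time of 60 min, tested at 1 uM, in the presence of a further agent that is not named here; a higher number here means faster removal of the compound, a lower number slower removal. Compound 2 stands highest of the two numbers; the nearest is compound 1, whose number is lower by a gap that lies beyond the scatter. Among the compounds with values here, no single-point step links the two, since they differ at several places at once, so their values show only that compound 2 is removed faster than compound 1 in this assay.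

Compound 3 `Cc1cc(-c2ccccn2)cc(C(=O)NNS(=O)(=O)c2ccccc2)c1F` has not yet been measured. It differs from compound 2 in one place: pyridin-2-yl in place of pyrimidin-2-yl on an aromatic carbon. Compound 1 also carries pyridin-2-yl, but it differs from compound 2 elsewhere as well, so its lower value cannot be read as the outcome of this ring change alone. Within the data shown here, with no measured pair isolating the change, the expected step of a 1.4-fold lower number from compound 2 to compound 3 (0.14 log units; within the scatter) is small, toward a lower number, and likely within the scatter. Compound 3 is therefore estimated at 200 uL/min, with a range from 100 uL/min to 400 uL/min.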

Compound 3, intrinsic clearance in a liver preparation (reported as CLH), per the amount of preparation that the assay uses in the Mus musculus assay: 424 uL/min
The estimate for compound 3 lay 2.1-fold (0.33 log units) below the measured number; the whole stated range lies below it.
By their numbers in the Mus musculus assay, from the lowest: compound 1; then compounds 2 and 3 (each within the scatter of the next).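

Within the data shown here, in the Mus musculus assay this pair gives the first reading of a single change on this aromatic carbon, and the step is small: a 1.5-fold higher number from compound 2 to compound 3 (0.18 log units; within the scatter), so pyridin-2-yl and pyrimidin-2-yl are not told apart here. In a physicochemical assay for solubility, read by nephelometry, in phosphate buffer, measured as kinetic solubility, at pH 6.5 (a lower number here means a less soluble compound, a higher number a more soluble compound), compound 2 gives 50 ug/mL and compound 3 gives 6.3 ug/mL. The same ring change, with one ring nitrogen fewer in the entering group, therefore leaves the removal numbers within the scatter in the Mus musculus assay but does separate the two compounds in the physicochemical assay, where pyrimidin-2-yl carries the more soluble compound: the measured solubility of compound 2, 50 ug/mL, and of compound 3, 6.3 ug/mL, a 7.9-fold lower number (0.90 log units; beyond the scatter)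

Going by these compounds, only these two aromatic rings are compared at this carbon, so how an amine or a carboxylic acid there would read in the Mus musculus assay and in the physicochemical assay stays open. On these data alone, the contributions of the methyl and fluoro groups on the shared ring also stay open, since compound 1 differs from compound 2 and compound 3 in more than one place.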